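The compounds below may be only part of what the source reports. "The series", "measured", "known", "first", "only" and "open" are said of these compounds alone.

Measured compounds:
compound 1 `COc1ccc(/C=C/C(=O)OC[C@H]2O[C@@H](O[C@H]3OC=C[C@@]4(O)[C@@H]3[C@](C)(O)C[C@@H]4O)[C@H](O[C@@H]3O[C@H](CO)[C@@H](O)[C@H](O)[C@H]3O)[C@@H](O)[C@@H]2O)cc1` – 12900 nM
compound 2 `CC(=O)O[C@]1(C)C[C@H](O)[C@H]2C=CO[C@H](O[C@@H]3O[C@H](CO)[C@@H](O)[C@H](O)[C@H]3O)[C@H]21` – 52200 nM

In a functional assay for inhibition, with a stated time of 24 h (a higher number here means a weaker inhibitor, a lower number a stronger inhibitor), compound 1 gives 12900 nM and compound 2 gives 52200 nM, the higher of the two numbers, with the gap beyond the scatter. Compound 3 `C[C@@]1(O)C[C@H](O)[C@H]2C=CO[C@H](O[C@@H]3O[C@H](CO)[C@@H](O)[C@H](O)[C@H]3O)[C@H]21` differs from compound 2 in one place: hydrogen in place of acetyl on an oxygen on a saturated carbon. Within the data shown here, no step of this kind has been measured, so the expectation rests on the change alone. The expected step is a 1.0-fold lower number from compound 2 to compound 3 (0.02 log units; within the scatter), small, in no sure direction and within the scatter. Compound 3 is therefore estimated at 50000 nM, with a range from 20000 nM to 130000 nM.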

Compound 3, half-maximal inhibitory concentration: 36800 nM
Estimate against measurement, compound 3: 1.4-fold (0.13 log units) above; the measured number falls inside the stated range.
By their numbers in this assay, from the lowest: compound 1; then compounds 3 and 2 (each within the scatter of the next).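

In this assay, hydrogen in place of acetyl on an oxygen on a saturated carbon gives a 1.4-fold lower number from compound 2 to compound 3 (0.15 log units; within the scatter). Among these compounds, this is the first single-change reading at this position: acetoxy and hydroxy cannot be told apart here, so the acetyl is not required to keep this level of inhibition. Nothing available explains the size of this step.

As far as these compounds go, it remains open whether a larger ester such as benzoyl, a methyl ether or an amine at this position would move the number beyond the scatter.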